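A few compounds are considered here, and "the series" means these few. Any claim that something is new, unique, unknown or untested is made for them only; others in the source may bear on it.

Measured in a functional assay on HL-60 cells (Homo sapiens) for cytotoxicity, read by MTT assay, with a stated time of 46 h; on this read-out higher numbers stand for weaker inhibition and lower numbers for stronger inhibition:
- compound 1 `O=C1/C(=C\c2ccncc2)C(c2ccccc2)Oc2ccccc21`: 1100 nM
- compound 2 `O=C1/C(=C\c2ccccc2)C(c2ccccc2)Oc2ccccc21`: 27300 nM
- compound 3 `O=C1/C(=C/c2ccccc2)C(c2ccccc2)Oc2ccccc21`: 33300 nM

Compound 2 stands at the weaker end of these numbers. It is level with its double-bond isomer, a 1.2-fold higher number from compound 2 to compound 3 (0.09 log units; within the scatter), and far from the pyridine-bearing compound, a 25-fold higher number from compound 1 to compound 2 (1.39 log units; beyond the scatter).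

Compound 4 `Cc1ccc(/C=C2\C(=O)c3ccccc3OC2c2ccccc2)cc1` has methyl in place of hydrogen on an aromatic carbon, which turns phenyl to 4-methylphenyl: methyl in place of hydrogen on an aromatic carbon.

Among the measured compounds shown here, only one measured step alters this same ring: a 25-fold higher number from compound 1 to compound 2 (1.39 log units; beyond the scatter). It is large, but it swaps pyridin-4-yl for phenyl, a different change from adding methyl, so it says little about the size of this one. The other step, a 1.2-fold higher number from compound 2 to compound 3 (0.09 log units; within the scatter), only changes the double bond and leaves this ring untouched. For the measured compounds named here, no measured step adds methyl anywhere, so the estimate is loose. The expectation is a 1.4-fold lower number from compound 2 to compound 4 (0.14 log units; within the scatter), with no shift beyond the scatter in this assay. The estimated value for compound 4 is 20000 nM, with an expected range of 8000 nM to 45000 nM.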

Compound 4, half-maximal inhibitory concentration: 40800 nM
The estimate for compound 4 lay 2.0-fold (0.31 log units) below the measured number, within the range that was stated.
By their numbers in this assay, from the lowest: compound 1; then compounds 2, 3 and 4 (each within the scatter of the next).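

In this assay, among the compounds shown here, the first added group on this phenyl ring, a methyl para to a large group, gives a 1.5-fold higher number from compound 2 to compound 4 (0.17 log units; within the scatter) so compound 4 cannot be told apart from compound 2. The large gap to the pyridine-bearing compound remains with the methylated ring, at a 37-fold higher number from compound 1 to compound 4 (1.57 log units; beyond the scatter) so among these compounds only the pyridin-4-yl ring stands apart at this position. The information available on these compounds concerns only how the double bond is drawn and does not bear on this result.

As far as these compounds go, whether a larger or differently built group at this place, such as an amine, a carboxylic acid or a methoxy group, would shift the number remains open. Also open, from the compounds shown here alone, is whether pyridin-3-yl or pyridin-2-yl would match the low number of compound 1.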